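Trifluoromethoxy to trifluoromethyl: working notes on the series

A few compounds are considered here, and "the series" means these few. Any claim that something is new, unique, unknown or untested is made for them only; others in the source may bear on it.

Values in a functional assay on the whole organism with Rattus norvegicus as the target; a higher number here means that more compound is needed for the effect, a lower number that less compound is needed
Compound 1 `CC[S+]([O-])CCn1c(=N)sc2cc(C(C)(C)C)ccc21` gives > 10 mg/kg
Compound 2 `CC[S+]([O-])CCn1c(=N)sc2cc(OC(F)(F)F)ccc21` gives 1.2 mg/kg

Compound 1 gives > 10 mg/kg, which is a limit. Among the measured compounds shown here, compound 2, at 1.2 mg/kg, holds the only actual number so far. For the measured compounds named here, the single measured step, trifluoromethoxy in place of tert-butyl on an aromatic carbon, is an at least 8.3-fold lower number from compound 1 to compound 2 (0.92 log units; beyond the scatter). As far as these compounds go, its full size stays open, as one end of it is the limit of > 10 mg/kg in this assay, at which 1 of the 2 values shown sits.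

Compound 3 `CC[S+]([O-])CCn1c(=N)sc2cc(C(F)(F)F)ccc21` carries trifluoromethyl in place of trifluoromethoxy on that same aromatic carbon: trifluoromethyl in place of trifluoromethoxy on an aromatic carbon. The step to compound 2 shows that the group there can move the number, but it tests a different exchange and bears only loosely on this one. In this assay the expected step is a 1.7-fold higher number from compound 2 to compound 3 (0.22 log units; within the scatter), a small rise that may not clear the usual scatter. For compound 3 the estimate is 2 mg/kg, with an expected range of 0.7 mg/kg to 6 mg/kg.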

Compound 3, dose for half-maximal effect: 1.7 mg/kg
Estimate against measurement, compound 3: 1.2-fold (0.07 log units) above; measured number inside the range.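

In this assay, the exchange on this aromatic carbon gives a 1.4-fold higher number from compound 2 to compound 3 (0.15 log units; within the scatter), so the two fluorinated groups cannot be told apart at this position, and the oxygen of trifluoromethoxy makes no visible difference here. The exchange away from tert-butyl now has a second reading, with trifluoromethyl in place of tert-butyl giving an at least 5.8-fold lower number from compound 1 to compound 3 (0.76 log units; beyond the scatter). The full size of that step stays open, as one end of it is a limit: the limit of > 10 mg/kg in this assay, at which 1 of the 3 values shown sits.

With only tert-butyl and two fluorinated groups shown, it remains open how a smaller or unfluorinated substituent on the same aromatic carbon, such as a chlorine, a methoxy or an amine, would read. The compounds shown also share one side chain, so what a sulfone or a longer chain in place of the ethyl sulfoxide would do is unknown.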